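Swapping the aryl group on silicon: from methoxy to methyl

This account rests on a few compounds, and the source may have more. Where it says the series, first, only, none or still open, it means among the compounds named here.

Measured compounds:
- compound 1 `CCN(C/C=C/C#CC(C)(C)C)Cc1cccc(OC[Si](C)(C)c2ccc(Cl)cc2)c1` — 400 nM
- compound 2 `CCN(C/C=C/C#CC(C)(C)C)Cc1cccc(OC[Si](C)(C)c2ccc(OC)cc2)c1` — 870 nM

In a functional assay on liver (Sus scrofa) for inhibition of squalene monooxygenase (Homo sapiens), using microsomes (on this read-out higher numbers stand for weaker inhibition and lower numbers for stronger inhibition), compound 2 gives the higher of the two numbers, and the gap between them is a 2.2-fold higher number from compound 1 to compound 2 (0.34 log units; beyond the scatter). Compound 3 `CCN(C/C=C/C#CC(C)(C)C)Cc1cccc(OC[Si](C)(C)c2cccc(C)c2)c1` is not yet measured. It differs from compound 2 by 3-methylphenyl in place of 4-methoxyphenyl on a silicon. For the measured compounds named here, no measured step changes this ring in the same way; the only step available, a 2.2-fold higher number from compound 1 to compound 2 (0.34 log units; beyond the scatter), altered a substituent on the same ring and was modest. The expectation is therefore a small step, a 1.6-fold lower number from compound 2 to compound 3 (0.20 log units; within the scatter), within or only just beyond the scatter. Compound 3 is estimated at 550 nM, with a range from 200 nM to 1500 nM.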

Compound 3, half-maximal inhibitory concentration: 3000 nM
Compound 3: the middle estimate sits 5.5-fold (0.74 log units) below what was measured, outside the stated range (above it).
By their numbers in this assay, from the lowest: compound 1; then compound 2; then compound 3.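

In this assay, the aryl group on silicon matters more than the first pair suggested: 3-methylphenyl in place of 4-methoxyphenyl gives a 3.4-fold higher number from compound 2 to compound 3 (0.54 log units; beyond the scatter), and in place of 4-chlorophenyl it gives a 7.5-fold higher number from compound 1 to compound 3 (0.88 log units; beyond the scatter). Both steps are larger than the one between the two earlier compounds, and both run towards weaker inhibition. Nothing available gives a reason for this loss.

Still open, as far as these compounds go, is whether the loss belongs to the methyl itself or to its place on the ring, a question that a 4-methylphenyl or 3-chlorophenyl group on silicon would address. From the compounds shown here alone, how a plain phenyl group would compare also remains unknown.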